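This account rests on a few compounds, and the source may have more. Where it says the series, first, only, none or still open, it means among the compounds named here.

Of the compounds shown here, three on a shared core have numbers so far in a physicochemical assay for solubility, at pH 7.4; a lower number here means a less soluble compound, a higher number a more soluble compound: compound 1 (`Cc1cc(NC(=O)Nc2ccc(Cl)c(Cl)c2)c2ccccc2n1`) gives 300 nM, compound 2 (`CCc1ccc(NC(=O)Nc2cc(C)nc3ccccc23)cc1`) gives 3300 nM and compound 3 (`Cc1cc(NC(=O)Nc2ccccc2N)c2ccccc2n1`) gives 51800 nM. Compound 2 therefore stands second highest of the three, with compound 1 lower and compound 3 higher, both gaps beyond the scatter.

Compound 4 (`Cc1cc(NC(=O)Nc2ccc(C(F)(F)F)cc2)c2ccccc2n1`) has not yet been measured. It carries trifluoromethyl in place of ethyl on an aromatic carbon, para to a large group: trifluoromethyl in place of ethyl on an aromatic carbon. Among the measured compounds shown here, no measured pair isolates such a change, so the expectation rests on a single loose comparison rather than a pattern. Compound 1, at 300 nM, also carries halogen on its aromatic ring of carbon only, though it differs from compound 4 in more than one place. A modest downward move in this assay, probably just beyond the scatter, is expected: the estimated change is a 2.8-fold lower number from compound 2 to compound 4 (0.44 log units; beyond the scatter). For compound 4 the estimated value is 1200 nM, with an expected range of 350 nM to 4000 nM.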

Compound 4, solubility: 100 nM
Estimate against measurement, compound 4: 12-fold (1.08 log units) above; the whole stated range lies above it.
By their numbers in this assay, from the lowest: compound 4; then compound 1; then compound 2; then compound 3.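

In this assay, among the compounds shown here, trifluoromethyl in place of ethyl on an aromatic carbon, para to a large group, gives a 33-fold lower number from compound 2 to compound 4 (1.52 log units; beyond the scatter) and forms the only step here between measured compounds that differ in one place. This position is therefore not indifferent to the group it carries: a swap between two small groups, with no ring, no hydrogen-bond donor or acceptor and no net charge on either side, produces a large step, well beyond the scatter. No supporting data bear on why the step is this large.

One step cannot show whether this drop is particular to trifluoromethyl or would follow other replacements of ethyl. As far as these compounds go, how a methoxy group, an amine or a carboxylic acid would read at this place in this assay remains open.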